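This account rests on a few compounds, and the source may have more. Where it says the series, first, only, none or still open, it means among the compounds named here.

Measured compounds:

- Compound 1, `O=C1C(=O)N(CCCCCn2cc(COc3cc(=O)oc4ccccc34)nn2)c2ccc(F)cc21`: 56%
- Compound 2, `O=C1C(=O)N(CCCCCn2cc(COc3cc(=O)oc4ccccc34)nn2)c2ccc(Br)cc21`: 39%
- Compound 3, `O=C1C(=O)N(CCCn2cc(COc3cc(=O)oc4ccccc34)nn2)c2ccc(F)cc21`: 69%

All three were tested in a functional assay on COLO 205 cells (Homo sapiens) for inhibition, read by sulforhodamine B assay, with a stated time of 48 h, tested at 50 uM; a higher number here means more inhibition of growth at the concentration tested, a lower number less inhibition of growth. Compound 1 and compound 2 share one core; compound 3 is built on a different core, and how the two cores differ is not broken down here. Within the first pair, one change was made: bromo in place of fluoro on an aromatic carbon. That change produced a number 17 percentage points lower from compound 1 to compound 2 (beyond the scatter). Of the three measured compounds, compound 3 shows the highest inhibition, and its steps to compound 1 and compound 2 are both beyond the scatter.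

Compound 4, `O=C1C(=O)N(CCCn2cc(COc3cc(=O)oc4ccccc34)nn2)c2ccc(Br)cc21`, has not yet been measured in this assay. It differs from compound 3 in exactly the way compound 2 differs from compound 1: bromo in place of fluoro on an aromatic carbon. The place is the same word for word in both pairs, so this is the same change applied to a second core. For the measured compounds named here, the expectation for compound 4 rests on the one measured instance of this change, the step from compound 1 to compound 2 in this assay, and on the starting point of compound 3 at 69%. If that change repeats its size, the step from compound 3 to compound 4 is expected to be about a number 17 percentage points lower from compound 3 to compound 4 (beyond the scatter), set beside the earlier step. On that basis, compound 4 is estimated to give 52% in this assay, with a likely range from 38% to 64%.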

Compound 4, percent growth inhibition at one concentration: 61%
For compound 4 the middle estimate is 9 percentage points below the measured one; low and high end bracket the measured number.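

In this assay, putting bromo in place of fluoro on the second core gives a number 8 percentage points lower from compound 3 to compound 4 (within the scatter), so on this core the effect of the change cannot be told apart from the ordinary spread of repeated measurements. Set beside the first core, the two steps point the same way and cannot be told apart from each other, so the result fits a change that carries over from one core to the other: the same change on two cores in this assay, a number 17 percentage points lower (beyond the scatter) from compound 1 to compound 2 and a number 8 percentage points lower (within the scatter) from compound 3 to compound 4, 9 percentage points apart, within the scatter of two such steps. For the compounds shown here, this does not show that the step has the same size on both cores, or that bromo truly lowers growth inhibition on the second core, since there are only two pairs, each a single reading at one concentration, and only the first step lies beyond the scatter.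

The compounds shown leave open how a different group on the same aromatic carbon, such as chloro, methoxy or an amine, would compare with fluoro and bromo. They also leave open whether the same swap would behave alike on a core with a longer chain, or in cell lines other than this one.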